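A few compounds are considered here, and "the series" means these few. Any claim that something is new, unique, unknown or untested is made for them only; others in the source may bear on it.

Of the compounds shown here, two of one shared core have been measured in a functional assay on CHO cells with adenosine receptor A1 (Homo sapiens) as the target, read by cAMP accumulation and immunoassay, with a stated time of 6 min, tested at 0.1 uM; a lower number here means a stronger effect, a higher number a weaker effect of the compound at the concentration tested. Compound 1 `Nc1scc(CN2CCN(c3ccc(OC(F)(F)F)cc3)CC2)c1C(=O)c1ccc(Cl)cc1` gives -13%. Compound 2 `Nc1scc(CN2CCN(c3cccc(F)c3)CC2)c1C(=O)c1cccc(C(F)(F)F)c1` gives -12%. Going by the values given here, of these two numbers, the one for compound 1 is the lower, but the gap to compound 2 lies within the scatter, so the two cannot be told apart; both sit at the low end of the scale, where the compound produces little effect at the concentration tested.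

Compound 3 `Nc1scc(CN2CCN(c3c(F)cccc3F)CC2)c1C(=O)c1ccc(Cl)cc1` has not yet been measured. It differs from compound 1 in one place: 2,6-difluorophenyl in place of 4-(trifluoromethoxy)phenyl on an amine nitrogen in a ring. Among the compounds with values here, no pair of measured compounds that differ in a single place is available, so the size of a step for such a change is unknown.

With compound 1 at -13% and compound 2 at -12% both showing little effect at the concentration tested, no step beyond the scatter is expected, and the estimated step is a number 3 percentage points higher from compound 1 to compound 3 (within the scatter). Compound 3 is therefore expected to give -10%, with a range from -30% to 10%.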

Compound 3, a percentage reported as activity, at one concentration (the size of the read-out at that concentration, not a potency): -23%
Estimate against measurement, compound 3: 13 percentage points above, and the stated range covers the measured number.
By their numbers in this assay, from the lowest: compounds 3, 1 and 2 (each within the scatter of the next, the first and the last beyond it).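

In this assay, going by these compounds alone, the exchange of 4-(trifluoromethoxy)phenyl for 2,6-difluorophenyl on an amine nitrogen in a ring provides the first step in this set that can be read at a single place (a number 10 percentage points lower from compound 1 to compound 3 (within the scatter)). The step stays within the scatter, so the two groups cannot be told apart here, even though the entering group has fewer heavy atoms, lacks the oxygen and the hydrogen-bond acceptor counted for the leaving group, and carries its fluorine directly on the aromatic ring. Nothing at hand explains why this exchange leaves the read-out within the scatter.

From the compounds shown here alone, whether this position would give a step beyond the scatter with a quite different group on that nitrogen, such as a benzyl group, a simple methyl or an aryl ring bearing a carboxylic acid, remains open. Also open, going by these compounds, is whether the same exchange would read the same way on the core of compound 2, and whether this result would hold at a concentration other than the one tested.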